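Swapping trifluoromethyl for methyl: what compound 4 may show

The compounds below may be only part of what the source reports. "The series", "measured", "known", "first", "only" and "open" are said of these compounds alone.

Compound 1 `O=C(CCCCC(S)CCS)Nc1ccccc1` gives 5.49%
Compound 2 `O=C(CCCCC(S)CCS)Nc1cccc(Cl)c1` gives "not active" (no number reported)
Compound 3 `O=C(CCCCC(S)CCS)Nc1cccc(C(F)(F)F)c1` gives 8.86%

In a functional assay on HO8910 cells (Homo sapiens) for inhibition, read by MTT assay, with a stated time of 24 h, tested at 10 ug/mL (on this read-out lower numbers stand for less inhibition of growth and higher numbers for more inhibition of growth at the one concentration tested), compound 3 gives 8.86% and lies within the scatter of compound 1, while compound 2 yielded no number. Compound 4 `Cc1cccc(NC(=O)CCCCC(S)CCS)c1` differs from compound 3 by one change: methyl in place of trifluoromethyl on an aromatic carbon on an aromatic carbon. Among the measured compounds shown here, the only measured step that bears on this is a number 3.4 percentage points higher from compound 1 to compound 3 (within the scatter) for trifluoromethyl in place of hydrogen. That step stays within the scatter, so no step beyond the scatter is expected in this assay for this change. A result without a number, as with compound 2, also remains possible. The expected step is a number 1.9 percentage points lower from compound 3 to compound 4 (within the scatter) as estimated here. Compound 4 is expected to give 7% with an estimated range from 0% to 16% as its likely span.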

Compound 4, percent growth inhibition at one concentration: "not active" (no number reported)
No number was reported for compound 4, so the estimate cannot be set against anything.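

In this assay compound 4 gives "not active" (no number reported) so no new step can be read against compound 3. The compounds shown leave open how methyl and trifluoromethyl compare here, and no evidence at hand bears on this result.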